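Amide nitrogen swap: from methylphenyl to thiazolyl

The compounds below may be only part of what the source reports. "The series", "measured", "known", "first", "only" and "open" are said of these compounds alone.

Compound 1, `CN(C)CCNC(=O)c1c(O)c2cccnc2n(-c2ccccc2)c1=O`, in a functional assay on the whole organism for inhibition, with Rattus norvegicus as the target, read by paw edema, at a dose of 100 mg/kg by the oral route; a lower number here means less inhibition, a higher number more inhibition at the dose given (going by the name of the read-out): 22.6%
Compound 2, `COc1cccc(NC(=O)c2c(O)c3cccnc3n(-c3ccccc3)c2=O)c1`, in this assay: 5.7%
Compound 3, `Cc1ccccc1NC(=O)c1c(O)c2cccnc2n(-c2ccccc2)c1=O`, in this assay: 11.7%

Among these three numbers compound 3 stands second highest. Its nearest neighbour is compound 2, and the step of a number 6 percentage points higher from compound 2 to compound 3 (within the scatter) stays within the scatter, whereas the step of a number 10.9 percentage points lower from compound 1 to compound 3 (beyond the scatter) lies beyond it. Compound 4, `O=C(Nc1nccs1)c1c(O)c2cccnc2n(-c2ccccc2)c1=O`, has not yet been measured in this assay. It differs from compound 3 in a single place: 1,3-thiazol-2-yl in place of 2-methylphenyl on an amide-type nitrogen.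

Two kinds of measured step bear on this change. Replacing the 2-(dimethylamino)ethyl on the amide-type nitrogen by a six-membered aromatic ring gave the steps of a number 16.9 percentage points lower from compound 1 to compound 2 (beyond the scatter) and a number 10.9 percentage points lower from compound 1 to compound 3 (beyond the scatter), both modest and beyond the scatter. Exchanging one aromatic ring for another on the same nitrogen gave the step of a number 6 percentage points higher from compound 2 to compound 3 (within the scatter), which stays within the scatter. The move to compound 4 is again an exchange of one aromatic ring for another on that nitrogen, so in this assay no step beyond the scatter is expected: the estimated step is a number 1.7 percentage points lower from compound 3 to compound 4 (within the scatter). For compound 4 the expected value is therefore 10%, with a range from 2% to 25%.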

Compound 4, a percentage reported as inhibition, in the whole organism at one dose (the size of the read-out at that dose, not a potency): 4.6%
For compound 4 the middle estimate is 5.4 percentage points above the measured one, and the stated range covers the measured number.
By their numbers in this assay, from the lowest: compounds 4, 2 and 3 (each within the scatter of the next); then compound 1.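

Moving from a six-membered carbon ring to a five-membered aromatic ring with 2 hetero atoms on the amide-type nitrogen produced no step beyond the scatter in this assay: the step of a number 7.1 percentage points lower from compound 3 to compound 4 (within the scatter) and the step of a number 1.1 percentage points lower from compound 2 to compound 4 (within the scatter) both stay within it, so compounds 2, 3 and 4 cannot be told apart here. The step of a number 18 percentage points lower from compound 1 to compound 4 (beyond the scatter) lies beyond the scatter and is modest, so the separation of compound 1 from the aromatic groups now holds for 1,3-thiazol-2-yl as well as for the two substituted phenyl groups. Nothing at hand explains why the groups on this nitrogen read as they do.

The compounds shown leave open whether the difference of compound 1 rests on its dimethylamino group or on the two-carbon chain itself, which a 2-hydroxyethyl chain, a 3-(dimethylamino)propyl chain or a carboxylic acid at the end of the chain on the same nitrogen would help to separate. They also leave open whether a basic amine attached to an aromatic ring, such as a 2-(dimethylamino)methylphenyl group, would read with compound 1 or with the other three.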